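This account rests on a few compounds, and the source may have more. Where it says the series, first, only, none or still open, it means among the compounds named here.

Compound 1 `CNC(=O)c1cncc(NS(=O)(=O)c2cc(Cl)ccc2OC)c1` is one of three compounds studied in an assay on isolated protein for inhibition of alkaline phosphatase, tissue-nonspecific isozyme (Homo sapiens); on this read-out lower numbers stand for stronger inhibition and higher numbers for weaker inhibition. For compound 1 the result is not a number but a limit of the assay, > 20000 nM, which places it at the limit of > 20000 nM in this assay, at which 1 of the 3 values shown sits. Compound 2 `COc1ccc(Br)cc1S(=O)(=O)Nc1cncc(C(N)=O)c1` gives 121 nM in this assay. Compound 3 `COc1ccc(C(F)(F)F)cc1S(=O)(=O)Nc1cccnc1` gives 3010 nM. Compound 4 `CCNC(=O)c1cncc(NS(=O)(=O)c2cc(Cl)ccc2OC)c1` has not yet been measured; it differs from compound 1 by methyl in place of hydrogen on a saturated chain carbon bound to an amide-type nitrogen. Going by the values given here, no measured pair shows this change, and since compound 1 itself gave only a limit, the starting point is uncertain. The step is expected to stay within the scatter, as a step that the limit leaves unreadable from compound 1 to compound 4, with no clear direction. Compound 4 is therefore estimated at about 25000 nM, somewhere between 5000 nM and 100000 nM, quite possibly again reported only as a limit.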

Compound 4, half-maximal inhibitory concentration: > 20000 nM
Compound 4: a limit, no number (the forecaster's own chance of this, stated with the estimate: 75%); the middle value does not contradict the limit.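

Going by these compounds alone, compound 1 and compound 4 each give only a limit of the assay, not a number, and no step between them can be read. As far as these compounds go, whether methyl in place of hydrogen changes inhibition at all stays open.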